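Working notes: shortening the ester linker, compound 3 to compound 4

A few compounds are considered here, and "the series" means these few. Any claim that something is new, unique, unknown or untested is made for them only; others in the source may bear on it.

Measured so far:
compound 1 `Cc1cc2c(cc1C(=O)c1ccc(C(=O)OCCCCOC(=O)c3ccc(C(=O)Nc4ccc5c(c4)C(C)(C)CCC5(C)C)cc3)cc1)C(C)(C)CCC2(C)C`: 24700 nM
compound 2 `C=C(c1ccc(C(=O)OCCCOC(=O)c2ccc(C(=O)Nc3ccc4c(c3)C(C)(C)CCC4(C)C)cc2)cc1)c1cc2c(cc1C)C(C)(C)CCC2(C)C`: 19300 nM
compound 3 `CCCC(CCC)C(=O)OCCCOC(=O)c1ccc(C(=O)Nc2ccc3c(c2)C(C)(C)CCC3(C)C)cc1`: 835000 nM

In a functional assay on HL-60 cells (Homo sapiens) for inhibition, read by MTT assay, with a stated time of 48 h (a higher number here means a weaker inhibitor, a lower number a stronger inhibitor), compound 1 gives 24700 nM and compound 2 gives 19300 nM. Where compound 1 and compound 2 carry a second aromatic ester, a branched aliphatic ester stands instead in compound 3; in this assay compound 3 gives 835000 nM. That is the highest number of the three, and its gaps to compound 1 and to compound 2 both lie well beyond the scatter, so compound 3 is the weakest inhibitor of the set.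

Compound 4 `CCCC(CCC)C(=O)OCCOC(=O)c1ccc(C(=O)Nc2ccc3c(c2)C(C)(C)CCC3(C)C)cc1` is not yet measured. It differs from compound 3 in one place:
((1-propylbutyl)carbonyl)oxy in place of (((1-propylbutyl)carbonyl)oxy)methyl on a saturated chain carbon, two bonds along the chain from an oxygen next to a carbonyl group
Going by the values given here, no pair of measured compounds differing in a single place is available, so the size of this step has no precedent here. The change removes one chain carbon and leaves the ester, the amide and the shared core untouched. The expected step is a 1.0-fold lower number from compound 3 to compound 4 (0.02 log units; within the scatter), that is, none beyond the scatter. For compound 4 in this assay the estimated value is 800000 nM, with a range from 300000 nM to 2000000 nM.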

Compound 4, half-maximal inhibitory concentration: 256000 nM
For compound 4 the middle estimate is 3.1-fold (0.49 log units) above the measured one; the measured number lies below the stated range.
By their numbers in this assay, from the lowest: compounds 2 and 1 (each within the scatter of the next); then compound 4; then compound 3.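

Going by these compounds alone, the step of a 3.3-fold lower number from compound 3 to compound 4 (0.51 log units; beyond the scatter) is the first single-place comparison, for (((1-propylbutyl)carbonyl)oxy)methyl changed to ((1-propylbutyl)carbonyl)oxy on a saturated chain carbon, two bonds along the chain from an oxygen next to a carbonyl group. In this assay the length of this chain therefore matters even with the ester, the amide and the shared core unchanged, although the step is only modest. No measurement shown here bears on the origin of this step.

From the compounds shown here alone, whether a longer chain at this place would raise the number further remains open, as does whether the same shortening would carry over to the aromatic esters of compound 1 and compound 2. Going by these compounds, how an amine or a carboxylic acid in place of the branched ester would read in this assay also remains open.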